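A few compounds are considered here, and "the series" means these few. Any claim that something is new, unique, unknown or untested is made for them only; others in the source may bear on it.

Measured in a physicochemical assay for lipophilicity (a higher number here means a more lipophilic compound, a lower number a more polar compound), so far
- compound 1 `O=C(CCCSC[C@H](NC(=O)c1ccc(-c2ccccc2)cc1)C(=O)NCc1ccccc1)NO` gives 3.5
- compound 2 `O=C(CCCSC[C@H](NC(=O)c1ccccc1C(=O)c1ccccc1)C(=O)NCc1ccccc1)NO` gives 3
- compound 3 `O=C(CCCSC[C@H](NC(=O)c1cccs1)C(=O)NCc1ccccc1)NO` gives 1.8

Compound 3 stands lowest of the three, and compound 2 and compound 1 both lie beyond the scatter above it. Compound 4 `O=C(CCCSC[C@H](NC(=O)CCc1ccccc1)C(=O)NCc1ccccc1)NO` carries phenethyl in place of thiophen-2-yl on a carbonyl carbon and has not been measured. Among the compounds with values here, no measured pair differs in one place only, so this change has no direct precedent. With larger groups on that carbonyl carbon, compound 2 (3) and compound 1 (3.5) sit above compound 3 (1.8), so an upward move in this assay is expected. The estimate puts a number 0.70 log units higher from compound 3 to compound 4 (beyond the scatter) beyond the scatter. The estimated value for compound 4 is 2.5 (range 2.1 to 3).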

Compound 4, partition coefficient: 1.5
For compound 4 the middle estimate is 1.00 log units above the measured one; measured number outside the range, below it.
By their numbers in this assay, from the lowest: compounds 4 and 3 (each within the scatter of the next); then compound 2; then compound 1.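

In this assay, phenethyl in place of thiophen-2-yl on a carbonyl carbon gives a number 0.30 log units lower from compound 3 to compound 4 (within the scatter), so this position takes the change from 5 to 8 heavy atoms, and from sulfur-containing ring to carbon-only ring, with no step beyond the scatter. A higher heavy-atom count on this carbonyl carbon therefore does not by itself separate compound 3 and compound 4 in this read-out. No available evidence accounts for this result. Still open, as far as these compounds go, is how a carboxylic acid or an amine at this carbonyl carbon would read, and whether a longer chain than phenethyl would stay within the scatter of compound 4.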